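A few compounds are considered here, and "the series" means these few. Any claim that something is new, unique, unknown or untested is made for them only; others in the source may bear on it.

Values in a functional assay on NIH3T3 cells (Mus musculus); a lower number here means that less compound is needed, a higher number that more compound is needed for the effect:
- compound 1 `Cn1cncc1C(OCc1ccc(C#N)cc1-c1ccc(F)c(Cl)c1)c1ccc(C#N)nc1`: 46 nM
- compound 2 `Cn1cncc1C(OCc1ccc(C#N)cc1-c1cccc(Cl)c1)c1ccc(C#N)nc1`: 2.1 nM
- compound 3 `Cn1cncc1C(OCc1ccc(C#N)nc1-c1ccc(OC(F)(F)F)cc1)c1ccc(C#N)cc1`: 4 nM

Compound 2 gives 2.1 nM, which cannot be separated from the value of compound 3, and it lies far from compound 1. The next compound is compound 4 `Cn1cncc1C(OCc1ccc(C#N)cc1-c1cccc(OC(F)(F)F)c1)c1ccc(C#N)nc1`, with trifluoromethoxy in place of chloro on an aromatic carbon, meta to a large group: trifluoromethoxy in place of chloro on an aromatic carbon. Among the measured compounds shown here, no measured step covers this exchange. For the measured compounds named here, the one measured step, a 22-fold lower number from compound 1 to compound 2 (1.34 log units; beyond the scatter), is hydrogen in place of fluoro on an aromatic carbon, a different change, but its size argues for a wide range. Compound 3 also carries trifluoromethoxy and gives 4 nM, though its structure differs elsewhere too. The expected change is no more than scatter, with a 1.9-fold higher number from compound 2 to compound 4 (0.28 log units; within the scatter) as the estimated step. Compound 4 is expected at 4 nM, with an estimated range of 1 nM to 20 nM.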

Compound 4, half-maximal effective concentration: 24 nM
Compound 4: middle estimate off by 6.0-fold (0.78 log units), on the low side, outside the stated range (above it).
By their numbers in this assay, from the lowest: compounds 2 and 3 (each within the scatter of the next); then compounds 4 and 1 (each within the scatter of the next).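

In this assay this position does not take the exchange of chloro for trifluoromethoxy quietly: the change gives an 11-fold higher number from compound 2 to compound 4 (1.06 log units; beyond the scatter) on the 3-chlorophenyl group. Putting 3-(trifluoromethoxy)phenyl in place of 3-chloro-4-fluorophenyl gives a 1.9-fold lower number from compound 1 to compound 4 (0.28 log units; within the scatter) and so does not separate these two groups, leaving the 3-chlorophenyl group of compound 2 alone at the low end among these three. No supporting data bear on the size of this step. Open, as far as these compounds go, is whether methoxy or an amine at this position would stay close to compound 2 or fall with compound 1 and compound 4.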